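This account rests on a few compounds, and the source may have more. Where it says the series, first, only, none or still open, it means among the compounds named here.

Working notes on the series. In a functional assay on CHO-K1 cells for antagonist activity at transient receptor potential cation channel subfamily V member 1 (Homo sapiens), read by FLIPR (a lower number here means a stronger inhibitor, a higher number a weaker inhibitor), compound 1 `CC(C(=O)NCc1ccc(C(F)(F)F)nc1NCc1ccc(Cl)cc1)c1ccc(NS(C)(=O)=O)c(F)c1` gives 65.7 nM and compound 2 `CC(C(=O)NCc1ccc(C(F)(F)F)nc1N1CC=CCC1)c1ccc(NS(C)(=O)=O)c(F)c1` gives 0.3 nM. For the measured compounds named here, compound 2 holds the lower of the two numbers, and the single step between measured compounds, a 220-fold lower number from compound 1 to compound 2 (2.34 log units; beyond the scatter), is large: it accompanied an exchange of the ring group on the shared core. Compound 3 `CC(C(=O)NCc1ccc(C(F)(F)F)nc1N1CCC(C)(C)CC1)c1ccc(NS(C)(=O)=O)c(F)c1` is the next member, not yet measured. Its difference from compound 2 is a group of 8 heavy atoms (7 carbon, 1 nitrogen; one six-membered non-aromatic ring with 1 hetero atom) in place of a group of 6 heavy atoms (5 carbon, 1 nitrogen; one six-membered non-aromatic ring with 1 hetero atom), on an aromatic carbon. Going by the values given here, no measured step covers an exchange of one six-membered non-aromatic ring for another at this carbon; the one step available, a 220-fold lower number from compound 1 to compound 2 (2.34 log units; beyond the scatter), set a six-membered aromatic ring of carbon only against the ring of compound 2, and so marks only how far a change at this place has moved the number. The exchange in hand is smaller in kind, both groups being six-membered non-aromatic rings with one hetero atom on the same carbon. A step within or just beyond the scatter is expected, with a slight lean toward a higher number. Compound 3 is estimated at 0.6 nM, range 0.15 nM to 3 nM, meaning a 2.0-fold higher number from compound 2 to compound 3 (0.30 log units; within the scatter).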

Compound 3, inhibition constant: 0.3 nM
Compound 3: the middle estimate sits 2.0-fold (0.30 log units) above what was measured; the range from low to high includes it.
By their numbers in this assay, from the lowest: compounds 2 and 3 (each within the scatter of the next); then compound 1.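

In this assay, the exchange of one six-membered non-aromatic ring for another on this aromatic carbon now has a measured step (no change at the digits printed from compound 2 to compound 3 (within the scatter)): the double bond outside aromatic rings in the group of compound 2 is not required for a number at this level, and the group of 8 heavy atoms is accepted in place of the group of 6 without a step beyond the scatter. The second step (a 220-fold lower number from compound 1 to compound 3 (2.34 log units; beyond the scatter)) shows that the large separation from the (4-chlorobenzyl)amino group of compound 1 is not particular to the ring of compound 2, but holds for both six-membered non-aromatic rings shown, with compound 1 the only contrasting group. Nothing on hand gives a reason for either step.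

The compounds shown leave open how far this tolerance extends to rings with a second hetero atom, such as morpholin-4-yl or piperazin-1-yl, or to an open-chain amine such as diethylamino on the same carbon. They also leave open which part of the (4-chlorobenzyl)amino group goes with the higher number of compound 1, since a plain benzylamino group or a 4-(4-chlorophenyl)piperidin-1-yl group would be needed to separate the chlorine, the aromatic ring and the amine hydrogen.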